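A few compounds are considered here, and "the series" means these few. Any claim that something is new, unique, unknown or untested is made for them only; others in the source may bear on it.

For the measured compounds named here, compound 1 `COc1ccc(Nc2cncc(N3CC4CC(C3)N4)c2)cc1` is the stronger of the two compounds measured so far: in an assay on HEK293 cells for displacement of a labelled ligand from Neuronal acetylcholine receptor; alpha3/beta4 (Homo sapiens) (a lower number here means a stronger inhibitor, a higher number a weaker inhibitor), compound 1 gives 2.2 nM. Compound 2 `Oc1ccc(Nc2ccc(N3CC4CC(C3)N4)cn2)cc1`, which carries a hydroxy group and a differently built core, gives in this assay 165 nM. Going by the values given here, compound 3 `Fc1ccc(Nc2cncc(N3CC4CC(C3)N4)c2)cc1` keeps the core of compound 1 and changes only one group: fluoro in place of methoxy on an aromatic carbon. Among the compounds with values here, since no measured pair shows this swap, the step from compound 1 to compound 3 is expected to be small, at most a modest weakening, and compound 3 is estimated to give 5 nM, with a range from 1.5 nM to 20 nM, as the step of a 2.3-fold higher number from compound 1 to compound 3 (0.36 log units; beyond the scatter) expresses.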

Compound 3, inhibition constant: 1.25 nM
The estimate for compound 3 lay 4.0-fold (0.60 log units) above the measured number; measured number outside the range, below it.
By their numbers in this assay, from the lowest: compounds 3 and 1 (each within the scatter of the next); then compound 2.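

On this aromatic carbon, para to a large group, the swap gives a 1.8-fold lower number from compound 1 to compound 3 (0.25 log units; within the scatter) in this assay and so leaves fluoro and methoxy indistinguishable here. The oxygen and the hydrogen-bond acceptor of methoxy are therefore not required at this position for a low number. On these data alone, whether an amine, a carboxylic acid or a longer chain such as propoxy would hold the number at this place stays open. Nothing shown explains why the two groups match.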